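This account rests on a few compounds, and the source may have more. Where it says the series, first, only, none or still open, it means among the compounds named here.

Compound 1 `CCCCCCc1cccc(N2CCNCC2)n1` is a short series member carrying a hexyl chain on its core. Going by the values given here, in a functional assay on the whole organism with Mus musculus as the target, in the maximal electroshock model, with a stated time of 120 min (a higher number here means that more compound is needed for the effect, a lower number that less compound is needed), compound 1 gives 10 mg/kg, the lowest of the two numbers measured so far. Its nearest neighbour is compound 2 `CCCCCCCCCCc1cccc(N2CCNCC2)n1`, which in this assay gives 30 mg/kg; the step of a 3.0-fold higher number from compound 1 to compound 2 (0.48 log units; beyond the scatter) shows that extending the chain made more compound necessary. Compound 3 `c1cc(CC2CCCCC2)nc(N2CCNCC2)c1` has not yet been measured in this assay. It differs from compound 1 by cyclohexyl in place of pentyl on a saturated chain carbon bound to an aromatic carbon. Among the compounds with values here, the only measured step that bears on this change is the one from compound 1 to compound 2, which was modest but beyond the scatter; since the new group adds little length, a smaller shift is expected. Compound 3 is therefore estimated at 15 mg/kg, with a range from 5 mg/kg to 45 mg/kg. This estimate corresponds to an expected step of a 1.5-fold higher number from compound 1 to compound 3 (0.18 log units; within the scatter).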

Compound 3, minimum effective dose: 100 mg/kg
Compound 3: middle estimate off by 6.7-fold (0.82 log units), on the low side; the measured number lies above the stated range.
By their numbers in this assay, from the lowest: compound 1; then compound 2; then compound 3.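

In this assay, the change from pentyl to cyclohexyl on a saturated chain carbon bound to an aromatic carbon gives a 10-fold higher number from compound 1 to compound 3 (1.00 log units; beyond the scatter). The earlier step showed only what lengthening the straight chain does; this one shows that closing the end of the chain into a ring also raises the dose needed, even though the entering group holds 6 heavy atoms and the leaving group 5. Nothing measured here explains this rise.

The compounds shown leave open whether the higher number belongs to rings in general at this place or to the six-membered ring alone. A cyclopentyl ring or a phenyl ring in the same place, or a butyl chain in place of the hexyl chain of compound 1, would extend the comparison.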